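The source may hold more compounds than are shown below. What is called first, only, known or untested is meant among the compounds shown, and "the series" means these compounds.

Going by the values given here, in an ADME assay on liver for metabolic stability, with Liver microsome (Homo sapiens) as the target, read by LC-MS, using microsomes (a higher number here means faster removal of the compound, a lower number slower removal), compound 1 `O=C(NCc1cc(Cl)ccc1-n1cnnn1)[C@@H]1CC=NN1C(=O)[C@H](O)c1ccccc1F` gives 16 mL.min-1.g-1, the lower of the two numbers measured so far. The other measured compound, compound 2 `O=C(NCc1cc(Cl)ccc1-n1cnnn1)[C@@H]1[C@H]2C[C@H]2CN1C(=O)[C@H](O)c1ccccc1`, gives 61 mL.min-1.g-1, a higher number and a gap beyond the scatter. Compound 3 `CC(C)(C)[C@@H](O)C(=O)N1N=CC[C@H]1C(=O)NCc1cc(Cl)ccc1-n1cnnn1` has not yet been measured. It differs from compound 1 as follows: tert-butyl in place of 2-fluorophenyl on a saturated chain carbon bound to a carbonyl carbon and an oxygen on a saturated carbon. This is tert-butyl in place of 2-fluorophenyl on a saturated chain carbon bound to a carbonyl carbon and an oxygen on a saturated carbon. Among the compounds with values here, no measured pair shows this change. The expected step is small, a 1.3-fold higher number from compound 1 to compound 3 (0.10 log units; within the scatter), slightly upward and within the scatter. Compound 3 is estimated at 20 mL.min-1.g-1, with an expected range from 9 mL.min-1.g-1 to 45 mL.min-1.g-1.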

Compound 3, intrinsic clearance in microsomes: < 12 mL.min-1.g-1
Compound 3 was reported as a limit; the forecaster's own chance of this, stated with the estimate: 5%; at least 1.6-fold (0.22 log units) between middle value and limit.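

With tert-butyl in place of 2-fluorophenyl on a saturated chain carbon bound to a carbonyl carbon and an oxygen on a saturated carbon, this assay shows an at least 1.3-fold lower number from compound 1 to compound 3 (0.12 log units; that floor lies within the scatter). This position therefore does not need an aromatic ring for slow removal. The result for compound 3 is a limit, not a number: the limit of < 12 mL.min-1.g-1 in this assay, at which 1 of the 3 values shown sits.

As far as these compounds go, how large the step really is stays open, since only its floor is known. Also open, from the compounds shown here alone, is whether a methyl group or an amine on this carbon would keep removal as slow.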